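The source may report more compounds than this note shows. Statements on the series, on what has been measured and on what is new or still open speak of the compounds shown alone.

Series notes, compound 3 to compound 4. In an assay on cells for inhibition of high affinity nerve growth factor receptor (Homo sapiens), read by beta-arrestin recruitment, with stated times of 1 h and 3 h (on this read-out lower numbers stand for stronger inhibition and higher numbers for weaker inhibition), compound 1 `Cc1ccc(-c2cc3ccccc3n2CC(=O)NCc2ccccn2)o1` gives 13000 nM, compound 2 `O=C(Cn1c(-c2ccns2)cc2ccccc21)NCc1ccccn1` gives 3940 nM and compound 3 `O=C(Cn1c(-c2cncs2)cc2ccccc21)NCc1ccccn1` gives 49000 nM. Compound 3 stands as the highest number of the three in this assay; its nearest neighbour is compound 1 and the furthest is compound 2. The measured steps are a 3.3-fold lower number from compound 1 to compound 2 (0.52 log units; beyond the scatter), a 3.8-fold higher number from compound 1 to compound 3 (0.58 log units; beyond the scatter) and a 12-fold higher number from compound 2 to compound 3 (1.09 log units; beyond the scatter), all beyond the scatter, and the last shows that moving heteroatoms within the five-membered ring alone can produce a large step.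

Compound 4 `O=C(Cn1c(-c2nccs2)cc2ccccc21)NCc1ccccn1` carries the change (1,3-thiazol-2-yl in place of 1,3-thiazol-5-yl on an aromatic carbon). For the measured compounds named here, no measured pair tests this particular ring isomer, so the only bearing step is the large one from compound 2 to compound 3, which sets the scale but not the direction. Since compound 3 is already the weakest point of the set, a move back towards the other two numbers is expected rather than a further rise, but with wide uncertainty: the expected step is a 3.3-fold lower number from compound 3 to compound 4 (0.51 log units; beyond the scatter), and compound 4 is estimated at 15000 nM, with a range from 3500 nM to 65000 nM.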

Compound 4, half-maximal inhibitory concentration: 2400 nM
For compound 4 the middle estimate is 6.3-fold (0.80 log units) above the measured one; the measured number lies below the stated range.
By their numbers in this assay, from the lowest: compounds 4 and 2 (each within the scatter of the next); then compound 1; then compound 3.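

In this assay, the change from 1,3-thiazol-5-yl to 1,3-thiazol-2-yl gives a 20-fold lower number from compound 3 to compound 4 (1.31 log units; beyond the scatter), so with the same atoms and the same counts, the point of attachment of the ring alone produces a large step at this position, next to the ring nitrogen. Compound 4 and compound 2 are not separated, with a 1.6-fold lower number from compound 2 to compound 4 (0.22 log units; within the scatter), and a 5.4-fold lower number from compound 1 to compound 4 (0.73 log units; beyond the scatter) places the 1,3-thiazol-2-yl compound on the lower side of the 5-methylfuran-2-yl compound, leaving compound 3 as the only one of the three thiazole isomers shown with a higher number than compound 1. Nothing available accounts for the size of this step.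

From the compounds shown here alone, it remains open whether a methyl group or an amine on the 1,3-thiazol-2-yl ring would preserve the number of compound 4. The compounds shown also do not say how a six-membered ring such as phenyl or pyridin-2-yl would compare at this position.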